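Benzyloxy in place of hydrogen on the pendant ring

The source may report more compounds than this note shows. Statements on the series, on what has been measured and on what is new or still open speak of the compounds shown alone.

In a functional assay on MCF7 cells (Homo sapiens) for cytotoxicity, read by MTT assay, with a stated time of 24 h (on this read-out lower numbers stand for stronger inhibition and higher numbers for weaker inhibition), the three measured compounds gave the following numbers:
compound 1, `Cc1cc(O)c(C(=O)/C=C/c2ccc(Cl)cc2)c(-c2ccc(Cl)cc2)c1C(=O)/C=C/c1ccc(Cl)cc1`: 28000 nM
compound 2, `Cc1cc(O)c(C(=O)/C=C/c2ccc(Cl)cc2)c(-c2ccccc2)c1C(=O)/C=C/c1ccc(Cl)cc1`: 10000 nM
compound 3, `Cc1cc(O)c(C(=O)/C=C/c2ccc(Br)cc2)c(-c2ccc(OCc3ccccc3)cc2)c1C(=O)/C=C/c1ccc(Br)cc1`: 30000 nM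

Compound 2 stands lowest of the three numbers shown. Its nearest neighbour is compound 1, whose number is higher; the change from compound 1 to compound 2 is a 2.8-fold lower number from compound 1 to compound 2 (0.45 log units; beyond the scatter), hydrogen in place of chloro on an aromatic carbon. Compound 3 differs from compound 2 in more than one place, so only the two values themselves can be compared: compound 3 sits about as far above compound 2 as compound 1 does.

The unmeasured compound 4, `Cc1cc(O)c(C(=O)/C=C/c2ccc(Cl)cc2)c(-c2ccc(OCc3ccccc3)cc2)c1C(=O)/C=C/c1ccc(Cl)cc1`, differs from compound 2 by benzyloxy in place of hydrogen on an aromatic carbon. For the measured compounds named here, the one measured single step, from compound 1 to compound 2, removed a group from this same ring and gave a modestly lower number; going the other way, by adding a group there, is therefore expected to give a modestly higher number in this assay. Compound 3, which also carries benzyloxy on that ring, gives 30000 nM and points the same way, though its bromo groups leave that comparison loose.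

Compound 4 is accordingly estimated at 25000 nM, within a range of 10000 nM to 60000 nM. The step from compound 2 to compound 4 is thus expected to be a 2.5-fold higher number from compound 2 to compound 4 (0.40 log units; beyond the scatter).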

Compound 4, half-maximal inhibitory concentration: "not active" (no number reported)
No number was reported for compound 4, so the estimate cannot be set against anything.
By their numbers in this assay, from the lowest: compound 2; then compounds 1 and 3 (each within the scatter of the next).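

In this assay, for the compounds shown here, compound 4 was reported as "not active" without a number, so no step from compound 2 to compound 4 can be read. The compounds shown leave open how far benzyloxy in place of hydrogen on the pendant ring shifts the number when the other groups stay the same. Nothing shown offers an explanation for this result.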